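Swapping Ethynyl for Vinyl on the Ether Chain

A few compounds are considered here, and "the series" means these few. Any claim that something is new, unique, unknown or untested is made for them only; others in the source may bear on it.

Three related compounds have numbers in a functional assay on HeLa cells (Homo sapiens) for cytotoxicity, read by sulforhodamine B assay, with a stated time of 72 h; on this read-out lower numbers stand for stronger inhibition and higher numbers for weaker inhibition. Compound 1 `COc1cc(NC(=O)/C=C/c2cccc(O)c2)cc(OC)c1OC` gives 18700 nM, compound 2 `COc1cccc(/C=C/C(=O)Nc2cc(OC)c(OC)c(OC)c2)c1` gives 11300 nM, and compound 3 `C#CCOc1cccc(/C=C/C(=O)Nc2cc(OC)c(OC)c(OC)c2)c1` gives 2000 nM, the lowest of the three. Compound 4 `C=CCOc1cccc(/C=C/C(=O)Nc2cc(OC)c(OC)c(OC)c2)c1` has not yet been measured. Its difference from compound 3 is vinyl in place of ethynyl on a saturated chain carbon bound to an oxygen on an aromatic ring; in short, vinyl in place of ethynyl on a saturated chain carbon bound to an oxygen on an aromatic ring.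

Among the compounds with values here, the closest precedent is a 5.7-fold lower number from compound 2 to compound 3 (0.75 log units; beyond the scatter), where ethynyl replaces hydrogen at this same place. The step of a 9.4-fold lower number from compound 1 to compound 3 (0.97 log units; beyond the scatter) is also relevant, whereas a 1.7-fold lower number from compound 1 to compound 2 (0.22 log units; within the scatter) shows no clear change. Within the data shown here, no measured compound yet carries vinyl here, so this is a judgement. Vinyl keeps the chain's length but removes the triple bond, so part of the drop seen with ethynyl may remain. The expected step is a 1.8-fold higher number from compound 3 to compound 4 (0.24 log units; within the scatter), a small move to a higher number that may stay within the scatter. For compound 4 the estimate is 3500 nM, with an expected range of 1500 nM to 8000 nM.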

Compound 4, half-maximal inhibitory concentration: 5400 nM
The estimate for compound 4 lay 1.5-fold (0.19 log units) below the measured number; the measured number falls inside the stated range.
By their numbers in this assay, from the lowest: compound 3; then compound 4; then compounds 2 and 1 (each within the scatter of the next).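

In this assay the kind of bond in the chain on this oxygen matters, not only the presence of the chain: a 2.7-fold higher number from compound 3 to compound 4 (0.43 log units; beyond the scatter) shows that propargyl cannot be exchanged for allyl without a measurable cost. Allyl still keeps part of the gain, with a 2.1-fold lower number from compound 2 to compound 4 (0.32 log units; beyond the scatter) and a 3.5-fold lower number from compound 1 to compound 4 (0.54 log units; beyond the scatter), so among these compounds both unsaturated chains give lower numbers than methyl or hydrogen on this oxygen. Nothing measured here explains why propargyl gives the lowest number.

From the compounds shown here alone, it remains open whether a fully saturated propyl chain would keep any of this gain, which would show how much depends on the multiple bond itself. Also open, going by these compounds, is how a longer chain ending in a triple bond, or a chain ending in an amine, would behave at this oxygen.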